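The source may report more compounds than this note shows. Statements on the series, on what has been measured and on what is new or still open speak of the compounds shown alone.

Measured compounds:
Compound 1, `CSc1cccc(CCCCCC(=O)N2CCOC2=O)c1`, 12800 nM
Compound 2, `O=C(CCCCCc1ccc(I)cc1)N1CCOC1=O`, > 20000 nM

In an assay on HEK293 cells for inhibition of N-acylethanolamine-hydrolyzing acid amidase (Rattus norvegicus), read by LC-MS, with a stated time of 30 min (a higher number here means a weaker inhibitor, a lower number a stronger inhibitor), compound 1 gives 12800 nM. For compound 2 this assay returns only a limit, > 20000 nM, and compound 2 thus sits at the limit of > 20000 nM in this assay, at which 1 of the 2 values shown sits. Compound 3, `Nc1ccc(CCCCCC(=O)N2CCOC2=O)cc1`, differs from compound 2 by amino in place of iodo on an aromatic carbon. Within the data shown here, with no step between measured compounds to lean on, the account expects no gain beyond the scatter, and likely a value again at the limit; the expected step is a step that the limit leaves unreadable from compound 2 to compound 3. Compound 3 is estimated at 30000 nM, between 10000 nM and 100000 nM.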

Compound 3, half-maximal inhibitory concentration: 15700 nM
Compound 3: middle estimate off by 1.9-fold (0.28 log units), on the high side, within the range that was stated.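

In this assay the value of compound 2, > 20000 nM, is a limit and not a number. Amino in place of iodo on an aromatic carbon, para to a large group, gives an at least 1.2-fold lower number from compound 2 to compound 3 (0.10 log units; that floor lies within the scatter). This position thus yields a readable value with amino, while the true size of the step stays unknown: the limit of > 20000 nM in this assay, at which 1 of the 3 values shown sits.

Open, as far as these compounds go, is whether a hydroxyl, a methoxy group or a carboxylic acid at this position would give a lower number than amino. Also open, from the compounds shown here alone, is whether a longer chain would shift the reading.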